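Cytotoxicity notes on the diaryl triazine piperazine series

The source may hold more compounds than are shown below. What is called first, only, known or untested is meant among the compounds shown, and "the series" means these compounds.

Measured so far in an ADME assay on NIH3T3 cells (Mus musculus) for cytotoxicity, read by MTT assay, with a stated time of 24 h; on this read-out higher numbers stand for weaker inhibition and lower numbers for stronger inhibition:
compound 1 `COc1cccc(N2CCN(CC(=O)N3CCN(c4nnc(-c5ccccc5)c(-c5ccccc5)n4)CC3)CC2)c1` gives 361000 nM;
compound 3 `COc1ccccc1N1CCN(CC(=O)N2CCN(c3nnc(-c4ccc(C)cc4)c(-c4ccc(C)cc4)n3)CC2)CC1` gives 133000 nM.
Compound 2 `COc1ccc(N2CCN(CC(=O)N3CCN(c4nnc(-c5ccccc5)c(-c5ccccc5)n4)CC3)CC2)cc1` reaches only a limit of the assay, > 910000 nM, as recorded in the limit of > 910000 nM in this assay, at which 1 of the 3 values shown sits.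

Compound 3 therefore stands lowest of the two numbers in this assay; its nearest neighbour is compound 1, which lies higher by a step beyond the scatter. Compound 4 `Cc1ccc(-c2nnc(N3CCN(C(=O)CN4CCN(c5ccc([N+](=O)[O-])cc5)CC4)CC3)nc2-c2ccc(C)cc2)cc1` is not yet measured. It differs from compound 3 by 4-nitrophenyl in place of 2-methoxyphenyl on an amine nitrogen in a ring.

Within the data shown here, only one measured step touches the same ring position: an at least 2.5-fold higher number from compound 1 to compound 2 (0.40 log units; beyond the scatter). That step moves a methoxy group within the phenyl ring and does not exchange it for another group, so it bears on the present change only loosely. Nothing measured here speaks to a nitro group at all. Given that the one measured step at this position went toward a higher number, compound 4 is expected to come out above compound 3 by a modest margin, a 2.1-fold higher number from compound 3 to compound 4 (0.32 log units; beyond the scatter), with a real chance that this assay returns only a limit. The estimate for compound 4 in this assay is 280000 nM, within a range of 90000 nM to 900000 nM.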

Compound 4, half-maximal inhibitory concentration: > 844000 nM
Compound 4: only a limit was reported (the forecaster's own chance of this, stated with the estimate: 30%); middle value at least 3.0-fold (0.47 log units) from the limit.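

In this assay, the exchange of 2-methoxyphenyl for 4-nitrophenyl on the amine nitrogen in the ring moves the number further than the position alone had shown, giving an at least 6.3-fold higher number from compound 3 to compound 4 (0.80 log units; beyond the scatter). Compound 4 is recorded only as a limit: the limit of > 844000 nM in this assay, at which 1 of the 4 values shown sits.

Read together with an at least 2.5-fold higher number from compound 1 to compound 2 (0.40 log units; beyond the scatter), this makes two steps at this position that run toward a higher number, each with a group at the 4-position of the phenyl ring entering, and no compound shown goes against them.

From the compounds shown here alone, the step to compound 4 changes the group and its place on the phenyl ring in a single exchange, so the share of each remains open, and the full size of both steps remains open as well, since each can be read from one side only. Going by these compounds, it is also open whether an amine or a carboxylic acid at the 4-position of the phenyl ring, or a nitro group at the 2-position, would give a measurable number in this assay or would likewise end at a limit.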